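Replacing 3-Fluorophenyl with 4-(Trifluoromethyl)phenyl on the Core

This account rests on a few compounds, and the source may have more. Where it says the series, first, only, none or still open, it means among the compounds named here.

Compound 1 `COc1cc2ncnc(Nc3cccc(F)c3)c2cc1OCCCCC(=O)Nc1ccc(S(N)(=O)=O)cc1` carries a 3-fluorophenyl on a nitrogen of the shared core. In a functional assay on NCI-H1975 cells (Homo sapiens) for antiproliferative activity, read by MTT assay, with a stated time of 72 h (a higher number here means a weaker inhibitor, a lower number a stronger inhibitor), compound 1 gives > 40000 nM, which is a limit of the assay rather than a number (the limit of > 40000 nM in this assay, at which 1 of the 3 values shown sits). Compound 2 `COc1cc2ncnc(Nc3ccc(Cl)cc3)c2cc1OCCCCC(=O)Nc1ccc(S(N)(=O)=O)cc1` gives 31800 nM. Compound 3 `COc1cc2ncnc(Nc3ccc(OC(F)(F)F)cc3)c2cc1OCCCCC(=O)Nc1ccc(S(N)(=O)=O)cc1` gives 8770 nM. Compound 4 `COc1cc2ncnc(Nc3ccc(C(F)(F)F)cc3)c2cc1OCCCCC(=O)Nc1ccc(S(N)(=O)=O)cc1` differs from compound 1 in one place: 4-(trifluoromethyl)phenyl in place of 3-fluorophenyl on a nitrogen on an aromatic ring. The step of an at least 1.2-fold lower number from compound 1 to compound 2 (0.09 log units; that floor lies within the scatter) stays within the scatter, whereas an at least 4.5-fold lower number from compound 1 to compound 3 (0.65 log units; beyond the scatter) goes beyond it, and a 3.6-fold lower number from compound 2 to compound 3 (0.56 log units; beyond the scatter) is also modest. Since the 4-(trifluoromethyl)phenyl of compound 4 resembles the 4-(trifluoromethoxy)phenyl of compound 3 more than the 4-chlorophenyl of compound 2, compound 4 is expected to show a step of an at least 3.3-fold lower number from compound 1 to compound 4 (0.52 log units; beyond the scatter). Compound 4 is estimated at 12000 nM, within 4000 nM to 38000 nM.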

Compound 4, half-maximal inhibitory concentration: 12000 nM
The estimate for compound 4 equals the measured number at the digits printed, within the range that was stated.
By their numbers in this assay, from the lowest: compounds 3 and 4 (each within the scatter of the next); then compound 2. At a limit, above all of these: compound 1.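

Compound 1 stands at a limit of the assay rather than at a number: the limit of > 40000 nM in this assay, at which 1 of the 4 values shown sits. Even so, 4-(trifluoromethyl)phenyl in place of 3-fluorophenyl gives an at least 3.3-fold lower number from compound 1 to compound 4 (0.52 log units; beyond the scatter), and trifluoromethyl in place of chloro gives a 2.7-fold lower number from compound 2 to compound 4 (0.42 log units; beyond the scatter). Trifluoromethyl in place of trifluoromethoxy gives a 1.4-fold higher number from compound 3 to compound 4 (0.14 log units; within the scatter), so compounds 3 and 4 cannot be told apart in this assay, and both differ from compound 2 beyond the scatter.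

The compounds shown leave open how a nitrile or an amine in place of trifluoromethyl would behave on this ring.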